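Removing a methoxy group from an inactive pair

The source may report more compounds than this note shows. Statements on the series, on what has been measured and on what is new or still open speak of the compounds shown alone.

Measured so far:
compound 1, `O=C(CCN1C(=O)CSc2ccccc21)N1CCN(c2ccccc2F)CC1`, > 100000 nM
compound 2, `COc1ccccc1N1CCN(CCCNC(=O)CCN2C(=O)CSc3ccccc32)CC1`, > 100000 nM

Both measured compounds share the same core and were tested in a functional assay on IMR-32 cells (Homo sapiens) for inhibition, read by sulforhodamine B assay, with a stated time of 48 h; a higher number here means a weaker inhibitor of growth, a lower number a stronger inhibitor of growth. For compound 1 the result is only a limit, > 100000 nM, not a number. For compound 2 the result is likewise a limit, > 100000 nM, so compound 2 stands at the top edge of the scale with no measured number beneath it. Compound 3, `O=C(CCN1C(=O)CSc2ccccc21)NCCCN1CCN(c2ccccc2)CC1`, has not yet been measured. It differs from compound 2 by hydrogen in place of methoxy on an aromatic carbon. Among the compounds with values here, no step between two measured compounds is available here, so the size of this change cannot be read from a comparison. Because (the limit of > 100000 nM in this assay, at which 2 of the 2 values shown sit), the expected step that the limit leaves unreadable from compound 2 to compound 3 is none beyond the scatter, and compound 3 is expected to return another limit. The estimate for compound 3 in this assay is 150000 nM, within 40000 nM to 600000 nM.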

Compound 3, concentration for 50% growth inhibition: > 100000 nM
Compound 3 ended at the assay's limit; the forecaster's own chance of this, stated with the estimate: 85%; the middle value is on the limit's open side.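

No step can be read between compound 2 and compound 3, since both results in this assay are limits and not numbers: the limit of > 100000 nM in this assay, at which 3 of the 3 values shown sit.

The compounds shown leave open whether going from 2-methoxyphenyl to phenyl alters growth inhibition at all, and whether any compound with this shared core gives a measurable value.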